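Compound 3 to compound 4: trifluoromethyl replaces methyl

This account rests on a few compounds, and the source may have more. Where it says the series, first, only, none or still open, it means among the compounds named here.

In an ADME assay on Raji cells (Homo sapiens) for cytotoxicity, with a stated time of 72 h (a lower number here means that less compound is needed, a higher number that more compound is needed for the effect), compound 1 `Cc1cc(NC(=O)Nc2ccc(C(C)(C)C)cc2)c2ccccc2n1` gives > 25000 nM as a limit, not a number. Compound 2 `CCc1ccc(NC(=O)Nc2cc(C)nc3ccccc23)cc1` gives > 25000 nM as a limit too. Compound 3 `Cc1ccc(NC(=O)Nc2cc(C)nc3ccccc23)cc1` gives > 25000 nM as a limit as well, so it has no number of its own to start from. The whole measured set comes down to the limit of > 25000 nM in this assay, at which 3 of the 3 values shown sit, and nothing finer.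

Compound 4 `Cc1cc(NC(=O)Nc2ccc(C(F)(F)F)cc2)c2ccccc2n1` carries trifluoromethyl in place of methyl on an aromatic carbon, para to a large group (trifluoromethyl in place of methyl on an aromatic carbon). Three measured steps change the group at this same place. For the measured compounds named here, the first is a step that the two limits leave unreadable from compound 1 to compound 2 and the second is a step that the two limits leave unreadable from compound 1 to compound 3 while the third is a step that the two limits leave unreadable from compound 2 to compound 3 and none of them has a size that can be read. Tert-butyl, ethyl and methyl all leave the reading at the limit.

With a step that the two limits leave unreadable from compound 1 to compound 3 as the closest guide, no step beyond the scatter is expected in this assay and no direction can be given. The expected step is a number no higher from compound 3 to compound 4 (the limit leaves the size open) and it rests on limits alone. Compound 4 is estimated at 25000 nM with an expected range of 10000 nM to 40000 nM and will most likely be reported only as a limit.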

Compound 4, half-maximal effective concentration: 23000 nM
Estimate against measurement, compound 4: 1.1-fold (0.04 log units) above; measured number inside the range.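

In this assay compound 4, with trifluoromethyl at this position, is the only compound shown that gives a number instead of a limit, while the others stay at the limit: the limit of > 25000 nM in this assay, at which 3 of the 4 values shown sit. Measured against the earlier groups, this gives an at least 1.0-fold lower number from compound 3 to compound 4 (0.03 log units; that floor lies within the scatter), an at least 1.0-fold lower number from compound 2 to compound 4 (0.03 log units; that floor lies within the scatter) and an at least 1.0-fold lower number from compound 1 to compound 4 (0.03 log units; that floor lies within the scatter). Each of these is only a floor and lies within the scatter, and the steps among compound 1, compound 2 and compound 3 cannot be read, so the result shows that trifluoromethyl brings the reading into the measurable range but not that this position responds to a change of group by any step beyond the scatter.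

On these data alone, whether an amine, a carboxylic acid or a longer chain at this position would give a number clearly lower in this assay stays open. All four compounds keep the shared core and the urea link, so what a change anywhere else in the molecule would do is also left open.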